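A few compounds are considered here, and "the series" means these few. Any claim that something is new, unique, unknown or untested is made for them only; others in the source may bear on it.

Measured compounds in a functional assay on PC-3 cells (Homo sapiens) for antiproliferative activity, read by MTT assay, with a stated time of 72 h; a lower number here means a stronger inhibitor, a higher number a weaker inhibitor:
- compound 1 `CC/C=C/C(=O)Nc1cc2c(N3CCc4ccccc43)ncnc2cc1OC` gives 5890 nM
- compound 2 `CC/C=C/C(=O)Nc1cc2c(N3CCc4ccccc43)ncnc2cc1O[C@@H]1CCOC1` gives 9590 nM
- compound 3 `CCC/C=C/C(=O)Nc1cc2c(N3CCCc4ccccc43)ncnc2cc1OC` gives 2240 nM

Compound 1 stands second highest of the three numbers; compound 3 sits lower, beyond the scatter, while compound 2 lies within the scatter of compound 1. Compound 4 `COc1cc2ncnc(N3CCc4ccccc43)c2cc1NC(=O)/C=C/CN1CCCCC1` differs from compound 1 as piperidin-1-yl in place of methyl on a saturated chain carbon bound to a double-bonded chain carbon. Going by the values given here, no measured step touches this position: a 1.6-fold higher number from compound 1 to compound 2 (0.21 log units; within the scatter) concerns the ether substituent and is within the scatter; compound 3 differs from compound 1 in more than one place, so its value gives no single-change reading. Without a bearing step, the estimate for compound 4 is set near compound 1 with a wide range: a 1.5-fold lower number from compound 1 to compound 4 (0.17 log units; within the scatter) in this assay is expected, giving an estimated 4000 nM (range 1000 nM to 15000 nM).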

Compound 4, half-maximal inhibitory concentration: 4180 nM
For compound 4 the middle estimate is 1.0-fold (0.02 log units) below the measured one; low and high end bracket the measured number.
By their numbers in this assay, from the lowest: compounds 3, 4, 1 and 2 (each within the scatter of the next, the first and the last beyond it).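

In this assay, methyl exchanged for piperidin-1-yl on a saturated chain carbon bound to a double-bonded chain carbon gives a 1.4-fold lower number from compound 1 to compound 4 (0.15 log units; within the scatter) at this place. The position therefore holds a group of 6 heavy atoms with a six-membered non-aromatic ring without a step beyond the scatter, a reading the ether step could not give. Nothing available explains this result.

Going by these compounds, whether a morpholin-4-yl ring, a dimethylamino group or a carboxylic acid at this place would stay within the scatter of compound 1 remains open. So does the reading of piperidin-1-yl on the core of compound 3.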